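The source may report more compounds than this note shows. Statements on the series, on what has been measured and on what is new or still open speak of the compounds shown alone.

Working notes on the series. Compound 3 `CNC(=O)c1cc(Oc2ccc3nc(Nc4cccc(OC(F)(F)F)c4)ncc3c2)ccn1` carries a 3-(trifluoromethoxy)phenyl group on a nitrogen on an aromatic ring. In an ADME assay on Caco-2 cells (Homo sapiens) for permeability, in the apical to basolateral direction (on this read-out lower numbers stand for lower permeability and higher numbers for higher permeability), compound 3 gives < 1 10^-6 cm/s, which is a limit of the assay and not a number. Compound 1 `CCc1ccccc1Nc1ncc2cc(Oc3ccnc(C(=O)NC)c3)ccc2n1` gives < 1 10^-6 cm/s in this assay, likewise a limit. Compound 2 `CNC(=O)c1cc(Oc2ccc3nc(Nc4cccc(C(F)(F)F)c4)ncc3c2)ccn1` gives < 1 10^-6 cm/s in this assay, again a limit. Because (the limit of < 1 10^-6 cm/s in this assay, at which 3 of the 3 values shown sit), no step among these three compounds can be read: a step that the two limits leave unreadable from compound 1 to compound 2, a step that the two limits leave unreadable from compound 1 to compound 3 and a step that the two limits leave unreadable from compound 2 to compound 3 all remain of unreadable size.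

The next compound, compound 4 `CNC(=O)c1cc(Oc2ccc3nc(Nc4ccc(C(C)C)cc4)ncc3c2)ccn1`, differs from compound 3 in one place: 4-isopropylphenyl in place of 3-(trifluoromethoxy)phenyl on a nitrogen on an aromatic ring. Going by the values given here, every measured step runs between two limits and gives no readable size for a change at this position, so no direction beyond the scatter can be drawn from them; they show only that compound 1, compound 2 and compound 3 all sit at the limit in this assay. The step expected from compound 3 to compound 4 is therefore an at least 1.5-fold higher number from compound 3 to compound 4 (0.17 log units; that floor lies within the scatter), with a fair chance that only a limit is reported once more. For compound 4 the estimate in this assay is 1.5 10^-6 cm/s, with a range from 0.3 10^-6 cm/s to 6 10^-6 cm/s.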

Compound 4, apparent permeability: < 1 10^-6 cm/s
Compound 4: only a limit was reported (the forecaster's own chance of this, stated with the estimate: 55%); at least 1.5-fold (0.17 log units) between middle value and limit.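

Compound 4 joins compound 1, compound 2 and compound 3 at a limit of the assay, so no step linking compound 4 to any of them can be read in this assay: the limit of < 1 10^-6 cm/s in this assay, at which 4 of the 4 values shown sit.

The compounds shown leave open the size and direction of any change of the group on the nitrogen in this assay, and how these four compounds order among themselves.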